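This account rests on a few compounds, and the source may have more. Where it says the series, first, only, none or still open, it means among the compounds named here.

Three compounds have been measured in a functional assay on A-375 cells (Homo sapiens) for antiproliferative activity, read by CCK-8 assay, with a stated time of 72 h, tested at 2 uM; on this read-out lower numbers stand for a weaker effect and higher numbers for a stronger effect at the one concentration tested:

Compound 1 `Nc1ccccc1NC(=O)c1ccc(CSC(=S)N2CCN(Cc3ccccn3)CC2)cc1`: 20.7%
Compound 2 `Nc1ccccc1NC(=O)c1ccc(CSC(=S)N2CCN(c3cccnc3)CC2)cc1`: 40.5%
Compound 3 `COc1ccc(N2CCN(C(=S)SCc3ccc(C(=O)Nc4ccccc4N)cc3)CC2)cc1`: 28.1%

Compound 3 stands second highest of the three. Its nearest neighbour is compound 1, and the step of a number 7.4 percentage points higher from compound 1 to compound 3 (within the scatter) lies within the scatter, so the two cannot be ranked. Compound 2 sits clearly higher, as the step of a number 12.4 percentage points lower from compound 2 to compound 3 (beyond the scatter) shows.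

Compound 4 `Nc1ccccc1NC(=O)c1ccc(CSC(=S)N2CCN(c3ccc(F)cc3)CC2)cc1` differs from compound 3 by fluoro in place of methoxy on an aromatic carbon. For the measured compounds named here, no measured step exchanges one substituent on that ring for another; the steps of a number 19.8 percentage points higher from compound 1 to compound 2 (beyond the scatter) and a number 7.4 percentage points higher from compound 1 to compound 3 (within the scatter) replace whole groups on the ring nitrogen and give no direct guide. With no evidence for a shift, the step of a number 0.1 percentage points lower from compound 3 to compound 4 (within the scatter) is expected to stay within the scatter. Compound 4 is therefore expected to give 28%, with a range from 15% to 42%.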

Compound 4, a percentage reported as inhibition, at one concentration (the size of the read-out at that concentration, not a potency): 20.9%
For compound 4 the middle estimate is 7.1 percentage points above the measured one; the range from low to high includes it.
By their numbers in this assay, from the lowest: compounds 1, 4 and 3 (each within the scatter of the next); then compound 2.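

In this assay, for the compounds shown here, the step from methoxy to fluoro, para to a large group, is the only direct exchange of one substituent for another on this ring, and a number 7.2 percentage points lower from compound 3 to compound 4 (within the scatter) does not separate the two. On the ring nitrogen, 4-fluorophenyl cannot be told apart from (pyridin-2-yl)methyl, with a number 0.2 percentage points higher from compound 1 to compound 4 (within the scatter), whereas pyridin-3-yl stands clearly apart from 4-fluorophenyl, with a number 19.6 percentage points lower from compound 2 to compound 4 (beyond the scatter). No measurement at hand accounts for these steps.

Still open, on these data alone, is whether an amine or a carboxylic acid at this place would give a number beyond the scatter of methoxy and fluoro. A single tested concentration also shows only how strong or weak the effect of these compounds is at that concentration.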